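A Lipophilicity Estimate for Compound 4

The compounds below may be only part of what the source reports. "The series", "measured", "known", "first", "only" and "open" are said of these compounds alone.

Compound 1 `O=C(Nc1cccc(Cl)c1)c1cc(C(F)(F)F)ccc1OCc1ccc(F)cc1`: 8.7
Compound 2 `N#Cc1cccc(NC(=O)c2cc(C(F)(F)F)ccc2OCc2ccc(F)cc2)c1`: 7.5
Compound 3 `CN1CCC(c2ccc(OCc3ccccc3)c(C(=O)Nc3ccnnc3)c2)CC1`: 2.3

These three compounds were measured in a physicochemical assay for lipophilicity, at pH 7.4; on this read-out lower numbers stand for lower lipophilicity and higher numbers for higher lipophilicity. Compound 3 stands lowest of the three, far below compound 2 and furthest from compound 1. Within the data shown here, the only single-point step among the measured compounds is a number 1.20 log units lower from compound 1 to compound 2 (beyond the scatter), and it concerns a different core from that of compound 3, so it says nothing direct about the change now in question.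

Compound 4 `CN1CC2(CCN(c3ccc(OCc4ccccc4)c(C(=O)Nc4ccnnc4)c3)CC2)C1` is the unmeasured compound. It differs from compound 3 in one place: a group of 10 heavy atoms (8 carbon, 2 nitrogen; one four-membered non-aromatic ring with 1 hetero atom, one six-membered non-aromatic ring with 1 hetero atom) in place of a group of 7 heavy atoms (6 carbon, 1 nitrogen; one six-membered non-aromatic ring with 1 hetero atom), on an aromatic carbon. The entering group carries more carbon atoms and an additional ring, as well as a second nitrogen. Among the measured compounds shown here, no measured pair shows a comparable change, so the expectation rests on the size of the group alone. The step is expected to be small, possibly within the scatter, and if anything upward. The estimate for compound 4 in this assay is 2.6, with a range from 1.8 to 3.4, which corresponds to an expected step of a number 0.30 log units higher from compound 3 to compound 4 (within the scatter).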

Compound 4, distribution coefficient: 2.2
The estimate for compound 4 lay 0.40 log units above the measured number, and the stated range covers the measured number.
By their numbers in this assay, from the lowest: compounds 4 and 3 (each within the scatter of the next); then compound 2; then compound 1.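

On this aromatic carbon, meta to the (pyridazin-4-yl)carbamoyl group and para to the benzyloxy group, this assay gives a number 0.10 log units lower from compound 3 to compound 4 (within the scatter) for the exchange of the 1-methylpiperidin-4-yl group for the larger group with a four-membered ring and a second nitrogen. The earlier compounds shown here held no change at this position, and this first one shows that the read-out can stay within its scatter even though the group gains heavy atoms and a ring. Nothing measured here accounts for this result.

Going by these compounds, whether an open-chain amine, a carboxylic acid or a phenyl ring at this position would also leave the number within the scatter remains open. A single step on one core also cannot show whether this exchange would behave the same way on a different core.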